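A few compounds are considered here, and "the series" means these few. Any claim that something is new, unique, unknown or untested is made for them only; others in the source may bear on it.

In a functional assay on LoVo cells (Homo sapiens) for inhibition, read by MTT assay, with a stated time of 48 h (a lower number here means a stronger inhibitor, a higher number a weaker inhibitor), compound 1 (`C[Se]c1ccc(N(C)c2nc(C3CC3)nc3ccccc23)cc1`) gives 11 nM as its result. Compound 2 (`COc1ccc(N(C)c2nc(C)nc3ccccc23)cc1OCCCCCC[Se]C#N`) gives 8580 nM in the same test, the higher of the two numbers and far beyond the scatter. Compound 3 (`COc1ccc(N(C)c2nc(C)nc3ccccc23)cc1OCC[Se]C#N`) differs from compound 2 by a group of 3 heavy atoms (1 carbon, 1 nitrogen, 1 selenium; no ring) in place of a group of 7 heavy atoms (5 carbon, 1 nitrogen, 1 selenium; no ring), on a saturated chain carbon, two bonds along the chain from an oxygen on an aromatic ring on a saturated chain carbon, two bonds along the chain from an oxygen on an aromatic ring. Going by the values given here, no measured pair shows a change of this kind, so only a modest expected move is proposed, an estimated 2.9-fold lower number from compound 2 to compound 3 (0.46 log units; beyond the scatter) towards a lower number. In this assay compound 3 is expected at 3000 nM with a range of 700 nM to 12000 nM around that estimate.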

Compound 3, half-maximal inhibitory concentration: 19 nM
For compound 3 the middle estimate is 160-fold (2.20 log units) above the measured one, and the stated range ends above it.
By their numbers in this assay, from the lowest: compounds 1 and 3 (each within the scatter of the next); then compound 2.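

In this assay, this place on a saturated chain carbon, two bonds along the chain from an oxygen on an aromatic ring, proves highly sensitive: the group of 3 heavy atoms in place of the group of 7 heavy atoms gives a 450-fold lower number from compound 2 to compound 3 (2.65 log units; beyond the scatter). Both groups hold a selenium and a nitrile and differ only in their carbon content, so shortening the chain alone accounts for this step. Nothing shown explains why the step is so large.

On these data alone, how a chain of intermediate length would behave here remains open. So does whether a sulfur in place of the selenium, or an amine in place of the nitrile, would keep the number low.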